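Benzyl substitution on the shared core: bromo to methoxy

A few compounds are considered here, and "the series" means these few. Any claim that something is new, unique, unknown or untested is made for them only; others in the source may bear on it.

Compound 3 `OC[C@H]1O[C@@H](n2cnc3c(NCc4ccc(Br)cc4)ncnc32)[C@H](O)[C@@H]1O` belongs to a set of three analogues that differ only in the group on a saturated chain carbon bound to a nitrogen on an aromatic ring. In a functional assay on B16 cells (Mus musculus) for antiproliferative activity, with a stated time of 72 h (on this read-out lower numbers stand for stronger inhibition and higher numbers for weaker inhibition), compound 3 gives > 166000 nM, which is a limit and not a measured number. Compound 1 `OC[C@H]1O[C@@H](n2cnc3c(NCc4ccc(Cl)cc4)ncnc32)[C@H](O)[C@@H]1O` gives > 166000 nM, also a limit. Compound 2 `OC[C@H]1O[C@@H](n2cnc3c(NCc4ccccc4Br)ncnc32)[C@H](O)[C@@H]1O` gives > 166000 nM, again a limit. All three sit at the limit of > 166000 nM in this assay, at which 3 of the 3 values shown sit, so the steps a step that the two limits leave unreadable from compound 1 to compound 3, a step that the two limits leave unreadable from compound 1 to compound 2 and a step that the two limits leave unreadable from compound 2 to compound 3 cannot be read in size or direction. Compound 4 `COc1ccccc1CNc1ncnc2c1ncn2[C@@H]1O[C@H](CO)[C@@H](O)[C@H]1O` brings (2-methoxyphenyl in place of 4-bromophenyl on a saturated chain carbon bound to a nitrogen on an aromatic ring). For the measured compounds named here, no measured step bears on this change, and no analogue in the set reaches a readable value. Compound 4 is therefore expected to stay at the limit, the step that the limit leaves unreadable from compound 3 to compound 4 being estimated as none beyond the scatter. The estimate for compound 4 is 200000 nM, ranging from 50000 nM to 800000 nM.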

Compound 4, half-maximal inhibitory concentration: > 166000 nM
Compound 4 gave a limit, no number; the forecaster's own chance of this, stated with the estimate: 80%; the middle value does not contradict the limit.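

In this assay compound 4 gives > 166000 nM, which is a limit. No new step can be read from compound 1, compound 2 or compound 3 to compound 4. The compounds shown leave open which group on the shared core, if any, gives a readable value: the limit of > 166000 nM in this assay, at which 4 of the 4 values shown sit.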